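This account rests on a few compounds, and the source may have more. Where it says the series, first, only, none or still open, it means among the compounds named here.

Compound 1 `O=C(O)c1cn(Cc2ccc(Br)cc2)c2ccccc2c1=O` has no result in a functional assay, tested at 50 uM; a lower number here means a weaker effect, a higher number a stronger effect of the compound at the concentration tested; its entry reads "not determined" (no result reported). Within the data shown here, compound 2 `O=C(O)c1cn(Cc2ccc(O)cc2)c2ccccc2c1=O` therefore stands as the only measured number, and in this assay compound 2 gives 30.4%. Compound 3 `O=C(O)c1cn(Cc2ccc(O)c(O)c2)c2ccccc2c1=O` differs from compound 2 by hydroxy in place of hydrogen on an aromatic carbon. Among the measured compounds shown here, no pair of measured compounds shows what such a change does, so in this assay the step is expected to be small, most likely within the scatter in either direction. Compound 3 is expected to give 30%, within a range of 10% to 55%. The expected step of a number 0.4 percentage points lower from compound 2 to compound 3 (within the scatter) is thus an estimate only.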

Compound 3, a percentage reported as activity, at one concentration (the size of the read-out at that concentration, not a potency): 61.9%
Compound 3: the middle estimate sits 31.9 percentage points below what was measured; the whole stated range lies below it.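

In this assay, hydroxy in place of hydrogen on an aromatic carbon, ortho to a hydroxy group and meta to a large group, brings a number 31.5 percentage points higher from compound 2 to compound 3 (beyond the scatter), so this position on the ring is clearly sensitive to the change. This rests on a single pair of compounds. Nothing available explains why the step is this large.

On these data alone, whether a methoxy group or an amine at this place would act as hydroxy does remains open. Compound 1 has no number, so the bromine it carries in place of the hydroxy of compound 2 cannot be compared.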